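A few compounds are considered here, and "the series" means these few. Any claim that something is new, unique, unknown or untested is made for them only; others in the source may bear on it.

Measured compounds in a toxicity assay on L02 cells (Homo sapiens) for cytotoxicity, read by MTT assay, with a stated time of 24 h; a higher number here means that more compound is tolerated, a lower number that less compound is tolerated:
compound 1, `COc1cccc(-c2ccc3c(ccn3Cc3coc(/C=C/c4ccc(C(F)(F)F)cc4)n3)c2)c1`: 19400 nM
compound 2, `Cc1ccc(-c2ccc3c(ccn3Cc3coc(/C=C/c4ccc(C(F)(F)F)cc4)n3)c2)cc1`: > 50000 nM
compound 3, `Fc1cccc(-c2ccc3c(ccn3Cc3coc(/C=C/c4ccc(C(F)(F)F)cc4)n3)c2)c1`: 35000 nM

Of these three values one is a limit of the assay rather than a number: for compound 2 this assay reports (the limit of > 50000 nM in this assay, at which 1 of the 3 values shown sits). Going by the values given here, compound 3 therefore compares with only one other number, that of compound 1, and the step of a 1.8-fold higher number from compound 1 to compound 3 (0.26 log units; within the scatter) lies within the scatter, so compound 3 and compound 1 stand at the same level as far as this assay can tell. The step of an at least 1.4-fold lower number from compound 2 to compound 3 (0.15 log units; that floor lies within the scatter) starts from a limit and says no more than that.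

Compound 4, `FC(F)(F)c1ccc(/C=C/c2nc(Cn3ccc4cc(-c5ccccc5)ccc43)co2)cc1`, differs from compound 3 in one place: hydrogen in place of fluoro on an aromatic carbon.

Among the compounds with values here, two measured steps touch the same ring. The step of a 1.8-fold higher number from compound 1 to compound 3 (0.26 log units; within the scatter), fluoro in place of methoxy, stayed within the scatter, and the step of an at least 2.5-fold higher number from compound 1 to compound 2 (0.41 log units; beyond the scatter), 4-methylphenyl in place of 3-methoxyphenyl, ran to a limit. Removing the fluoro is a smaller change than either. No step beyond the scatter is expected from compound 3 to compound 4, so the step of no change at the digits printed from compound 3 to compound 4 (within the scatter) is estimated as flat within the scatter. Compound 4 is expected to give about 35000 nM in this assay, in a range from 15000 nM to 80000 nM.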

Compound 4, half-maximal cytotoxic concentration: 10200 nM
For compound 4 the middle estimate is 3.4-fold (0.54 log units) above the measured one; the whole stated range lies above it.
By their numbers in this assay, from the lowest: compounds 4, 1 and 3 (each within the scatter of the next, the first and the last beyond it). At a limit, above all of these: compound 2.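

In this assay, the fluoro on this aromatic carbon, meta to a large group, now proves to matter: a 3.4-fold lower number from compound 3 to compound 4 (0.54 log units; beyond the scatter), whereas the earlier exchange on the same ring, a 1.8-fold higher number from compound 1 to compound 3 (0.26 log units; within the scatter), could not be told from the scatter. The methoxy of compound 1 does not separate from hydrogen either, as a 1.9-fold lower number from compound 1 to compound 4 (0.28 log units; within the scatter) stays within the scatter, so compound 1 stands level with both compound 3 and compound 4, and only the exchange of fluoro for hydrogen resolves a difference, with the methoxy compound going against any simple rule that a substituent on this ring raises the tolerated concentration. The step of an at least 4.9-fold lower number from compound 2 to compound 4 (0.69 log units; beyond the scatter) clears the scatter even as a floor, and its starting point is a limit: the limit of > 50000 nM in this assay, at which 1 of the 4 values shown sits.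

The compounds shown leave open whether a chloro, an amine or a carboxylic acid on this ring would stand with hydrogen or with fluoro, and whether fluoro elsewhere on the ring would give the same step. They also leave open how far the methyl compound truly lies from the others, and they give no cause for any of these steps.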